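The source may hold more compounds than are shown below. What is called first, only, known or untested is meant among the compounds shown, and "the series" means these compounds.

Three compounds share one core and differ only in the aryl group attached to it. Compound 1 `C(=C/c1nn2c(-c3ccncc3)nnc2s1)\c1ccco1` gives 67% in an assay for inhibition of histone-lysine N-methyltransferase, H3 lysine-79 specific (Homo sapiens), read by scintillation counting, with stated times of 15 min and 60 min, tested at 50 uM, in the presence of a further agent that is not named here; a lower number here means a weaker effect, a higher number a stronger effect of the compound at the concentration tested. Compound 2 `Fc1cccc(-c2nnc3sc(/C=C/c4ccco4)nn23)c1` gives 22%, and compound 3 `Cc1cccc(-c2nnc3sc(/C=C/c4ccco4)nn23)c1` gives 69%. Compound 3 therefore stands highest of the three numbers, though its gap to compound 1 is within the scatter, a number 2 percentage points higher from compound 1 to compound 3 (within the scatter), while the gap to compound 2 is large, a number 47 percentage points higher from compound 2 to compound 3 (beyond the scatter).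

The step to compound 4 `C(=C/c1nn2c(-c3ccccc3)nnc2s1)\c1ccco1` is hydrogen in place of methyl on an aromatic carbon, so the 3-methylphenyl of compound 3 becomes a phenyl. Going by the values given here, two measured steps bear on this. The step from fluoro to methyl on that same aromatic carbon was large, a number 47 percentage points higher from compound 2 to compound 3 (beyond the scatter), showing that the group on this ring can move the number strongly. The exchange of pyridin-4-yl for 3-methylphenyl, by contrast, changed little, a number 2 percentage points higher from compound 1 to compound 3 (within the scatter). Phenyl carries neither fluoro nor methyl, and nothing measured shows a bare hydrogen at this carbon, so the direction is uncertain; a moderate fall is expected, a number 14 percentage points lower from compound 3 to compound 4 (beyond the scatter). Compound 4 is therefore estimated at 55%, with a range from 30% to 75%.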

Compound 4, a percentage reported as inhibition, at one concentration (the size of the read-out at that concentration, not a potency): 79%
Compound 4: middle estimate off by 24 percentage points, on the low side; measured number above the stated range.
By their numbers in this assay, from the lowest: compound 2; then compounds 1, 3 and 4 (each within the scatter of the next, the first and the last beyond it).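

In this assay, taking the methyl off this carbon leaves the read-out within the scatter (a number 10 percentage points higher from compound 3 to compound 4 (within the scatter)), while the same carbon bearing fluoro gives a far lower number (a number 57 percentage points higher from compound 2 to compound 4 (beyond the scatter)), so the low value of compound 2 goes with the fluoro itself and not with the lack of a methyl. The unsubstituted phenyl also separates, modestly, from pyridin-4-yl (a number 12 percentage points higher from compound 1 to compound 4 (beyond the scatter)), a difference that the 3-methylphenyl comparison had not brought out. Nothing among the data available explains why fluoro stands apart from hydrogen and methyl here.

As far as these compounds go, whether chloro, methoxy or an amine on this carbon would follow fluoro or methyl remains open. So does whether fluoro on another carbon of the ring would give the same low number, and, as each read-out comes from one concentration, how the compounds compare in the strength of their effect at any other concentration.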